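This account rests on a few compounds, and the source may have more. Where it says the series, first, only, none or still open, it means among the compounds named here.

Working notes on the arylpiperazine series. The shared core of compound 1 `CCC1(CCCCN2CCN(c3ccccc3)CC2)C(=O)Nc2ccccc21` carries a phenyl on the piperazine nitrogen; in an assay on CHO cells for displacement of a labelled ligand from 5-hydroxytryptamine receptor 7 (Homo sapiens) (a higher number here means a weaker inhibitor, a lower number a stronger inhibitor), compound 1 gives 2.07 nM, the second highest of three numbers. Compound 3 `CCC1(CCCCN2CCN(c3ccc(F)cc3)CC2)C(=O)Nc2ccc(F)cc21` gives 1.5 nM in this assay, within the scatter of compound 1. Compound 2 `CCC1(CCCCN2CCN(c3ccc(Cl)cc3)CC2)C(=O)Nc2cc(F)c(Cl)cc21` gives 6.99 nM, a step beyond the scatter on the weaker side. Compound 4 `CCC1(CCCCN2CCN(c3ccc(C)c(Cl)c3)CC2)C(=O)Nc2ccccc21` differs from compound 1 by 3-chloro-4-methylphenyl in place of phenyl on an amine nitrogen in a ring. Going by the values given here, no measured pair shows this change alone, so its size is uncertain; the spread across compounds 1, 2 and 3 is modest. The expected step from compound 1 to compound 4 is a 1.4-fold higher number from compound 1 to compound 4 (0.16 log units; within the scatter), small and not clearly beyond the scatter. Compound 4 is estimated at 3 nM, between 1 nM and 9 nM.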

Compound 4, inhibition constant: 0.66 nM
Compound 4: the middle estimate sits 4.5-fold (0.66 log units) above what was measured; measured number outside the range, below it.
By their numbers in this assay, from the lowest: compound 4; then compounds 3 and 1 (each within the scatter of the next); then compound 2.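

Going by these compounds alone, on an amine nitrogen in a ring, 3-chloro-4-methylphenyl in place of phenyl gives a 3.1-fold lower number from compound 1 to compound 4 (0.50 log units; beyond the scatter) in this assay and is the only change in one place that can be read. This position therefore accepts the larger group, carrying chlorine and methyl, with a lower number rather than a loss. Nothing measured here accounts for the step.

On these data alone, whether the chlorine or the methyl alone carries the step stays open. So does the outcome of a carboxylic acid or a methoxy group on this phenyl.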